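The compounds below may be only part of what the source reports. "The series", "measured", "known", "first", "only" and "open" are said of these compounds alone.

Measured compounds in a functional assay on HO8910 cells (Homo sapiens) for inhibition, read by MTT assay, with a stated time of 24 h, tested at 1 ug/mL; a lower number here means less inhibition of growth, a higher number more inhibition of growth at the concentration tested:
- compound 1 `O=C(CCCCC(S)CCS)Nc1ccccc1` gives 6.38%
- compound 2 `O=C(CCCCC(S)CCS)Nc1ccc(OC(F)(F)F)cc1` gives 0.56%

Compound 1 holds the higher of the two numbers, but its nearest neighbour, compound 2, sits within the scatter of it: a number 5.8 percentage points lower from compound 1 to compound 2 (within the scatter). For the measured compounds named here, the series so far shows no step beyond the scatter.

Compound 3 `Cc1cccc(NC(=O)CCCCC(S)CCS)c1` is not yet measured. It differs from compound 1 in one place: methyl in place of hydrogen on an aromatic carbon. Going by the values given here, the only measured step that bears on this change is the one from compound 1 to compound 2, where a different group, trifluoromethoxy, entered the same ring on an aromatic carbon and the number did not move beyond the scatter. Among the compounds with values here, no methyl-for-hydrogen step has been measured, so there is no direct precedent; what the one comparable step shows is that a single substituent on that ring left this assay essentially unchanged.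

On that basis no step beyond the scatter is expected from compound 1 to compound 3, a number 1.4 percentage points lower from compound 1 to compound 3 (within the scatter). For compound 3 the estimate in this assay is 5%, with a range from -4% to 14%.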

Compound 3, percent growth inhibition at one concentration: 2.76%
For compound 3 the middle estimate is 2.2 percentage points above the measured one; measured number inside the range.
By their numbers in this assay, from the lowest: compounds 2, 3 and 1 (each within the scatter of the next).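

Methyl in place of hydrogen on an aromatic carbon, meta to a large group, now has a direct reading in this assay: a number 3.6 percentage points lower from compound 1 to compound 3 (within the scatter). Together with the trifluoromethoxy step, this gives two different groups on the ring of compound 1, and neither step leaves the scatter, so the absence of a clear step is no longer tied to trifluoromethoxy alone; the reading covers this one position and this one concentration, and compound 1 itself gives only 6.38%, which leaves little room for a downward step to show. Nothing on hand explains the result, and the reading stands as an observation only.

Still open, from the compounds shown here alone, is whether any group on this ring can take the number beyond the scatter in either direction, which an amine or a carboxylic acid on the same aromatic carbon, meta to a large group, would test. Also open, going by these compounds, is whether the series responds to changes away from the ring, such as a longer chain between the amide carbonyl and the two thiol groups.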